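Stereocentre inversion on the ring in a phosphoserine series

The source may hold more compounds than are shown below. What is called first, only, known or untested is meant among the compounds shown, and "the series" means these compounds.

For the measured compounds named here, compound 2 `N[C@@H](COP(=O)(O)O[C@H]1C=CCO[C@@H]1COC(=O)CCc1ccccc1OCc1cccc(Oc2ccccc2)c1)C(=O)O` is the one member of this series with a reported maximal response: in an assay on HEK293-A cells for agonist activity at probable G-protein coupled receptor 34 (Mus musculus), with a stated time of 1.5 h (on this read-out higher numbers stand for larger maximal responses and lower numbers for smaller maximal responses), compound 2 gives 11.7%. Compound 1 `N[C@@H](COP(=O)(O)OC[C@H]1OCCC[C@H]1OC(=O)CCc1ccc(OCc2cccc(Oc3ccccc3)c2)cc1)C(=O)O` is recorded in this assay as "not active" (no number reported), with no number attached, so compound 2 stands alone on the figures shown, and no step between two measured compounds is available for comparison. Compound 3 `N[C@@H](COP(=O)(O)O[C@@H]1C=CCO[C@@H]1COC(=O)CCc1ccccc1OCc1cccc(Oc2ccccc2)c1)C(=O)O` remains to be measured in this assay. It differs from compound 2 as follows: the two compounds have the same atoms and bonds; at least one stereo element is drawn with a configuration in one of them and without one in the other: 1 of 4 stereo elements differ; a stereocentre at a saturated ring carbon is drawn S in compound 2 and R in compound 3. Going by the values given here, with no measured step to lean on, the size of the move in this assay cannot be read from the series itself; a change of this kind is expected to stay within the usual scatter, in either direction. The step expected here is a number 0.3 percentage points higher from compound 2 to compound 3 (within the scatter). Compound 3 is therefore estimated at 12%, with a range from 0% to 30%.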

Compound 3, largest response reached (Emax), in percent of the reference or control that the assay uses: 12.4%
The estimate for compound 3 lay 0.4 percentage points below the measured number; measured number inside the range.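

In this assay, for the compounds shown here, the change of the stereocentre at a saturated ring carbon from S to R gives a number 0.7 percentage points higher from compound 2 to compound 3 (within the scatter), the first readable step. On this pair, the configuration at this carbon does not separate the maximal responses beyond the usual scatter, a point that compound 1, which has no number, could not show. This reading carries one caveat: the fact that one of compounds 2 and 3 is drawn with a defined configuration and the other without, at the place where they differ

On these data alone, it remains open whether a hydroxyl or a methyl group on this ring carbon would shift the maximal response beyond the scatter. Compound 1, with more than one difference from compound 2 and compound 3 and no number, stays outside any comparison.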